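Chloro substitution on the fused core of compound 1

A few compounds are considered here, and "the series" means these few. Any claim that something is new, unique, unknown or untested is made for them only; others in the source may bear on it.

Measured compounds:
compound 1 `ClCc1ccc(Cn2cnc3c(Cl)ncnc32)cc1`: 64600 nM
compound 2 `ClCc1cccc(Cn2cnc3c(Cl)ncnc32)c1`: 79400 nM

Among the compounds with values here, only two numbers exist so far in a functional assay on OVCAR-8 cells (Homo sapiens) for cytotoxicity, read by sulforhodamine B assay, with a stated time of 48 h; a higher number here means that more compound is tolerated, a lower number that less compound is tolerated. Compound 1 gives 64600 nM in this assay, the lower of the two, but compound 2, its nearest neighbour, differs from it only within the scatter, so no order between the two can be read and neither can be called the more tolerated.

The next compound, compound 3 `ClCc1ccc(Cn2cnc3c(Cl)nc(Cl)nc32)cc1`, keeps the shared core of compound 1 and differs from it in one place: chloro in place of hydrogen on an aromatic carbon. Within the data shown here, no measured pair in this small set shows what such a change does in this assay, so the expectation rests on the size of the change alone. A second chloro on the core is a small addition, and the step from compound 1 to compound 3 is expected to be modest, most likely a somewhat lower number, but it may also stay within the scatter.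

On that basis compound 3 is estimated at 40000 nM, with a range from 15000 nM to 110000 nM, which means an expected step of a 1.6-fold lower number from compound 1 to compound 3 (0.21 log units; within the scatter) from compound 1.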

Compound 3, concentration lethal to 50% of the cells: 72400 nM
For compound 3 the middle estimate is 1.8-fold (0.26 log units) below the measured one; low and high end bracket the measured number.
By their numbers in this assay, from the lowest: compounds 1, 3 and 2 (each within the scatter of the next).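

In this assay, chloro in place of hydrogen on the aromatic carbon between two ring nitrogen atoms gives a 1.1-fold higher number from compound 1 to compound 3 (0.05 log units; within the scatter) and this lies within the scatter, so the position carries the added chloro group without a readable change in the lethal concentration. Within the data shown here, this is the first step that differs in one place, and it adds a single observation for one group at one position, not a trend for the position as a whole. No supporting measurement is available to account for this result.

From the compounds shown here alone, whether an amine, a methoxy group or a longer chain on this same aromatic carbon would move the number beyond the scatter remains open, as the chloro group is the only replacement for hydrogen seen here. Going by these compounds, it is also open whether the same chloro change on compound 2 would again stay within the scatter, since this single pair says nothing about how the step reads on that isomeric side chain.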